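Methyl added to the aryl ring of the triazole substituent

This account rests on a few compounds, and the source may have more. Where it says the series, first, only, none or still open, it means among the compounds named here.

Compound 1 `N#CC1=C(N)Oc2c(c3nc4ccccc4nc3c3ccccc23)C12C(=O)N(Cc1cnnn1-c1ccc(Br)cc1)c1ccccc12` gives 44300 nM in a functional assay on A549 cells (Homo sapiens) for antiproliferative activity, read by MTT assay, with a stated time of 48 h; on this read-out higher numbers stand for weaker inhibition and lower numbers for stronger inhibition. Compound 2 `CCOc1ccccc1-n1nncc1CN1C(=O)C2(C(C#N)=C(N)Oc3c2c2nc4ccccc4nc2c2ccccc32)c2ccccc21` reaches only the limit of > 50000 nM in this assay, which is the same limit as the limit of > 50000 nM in this assay, at which 1 of the 3 values shown sits. Among the measured compounds shown here, the one measured step, an at least 1.1-fold higher number from compound 1 to compound 2 (0.05 log units; that floor lies within the scatter), therefore has a floor that lies within the scatter and sets no clear direction. Compound 3 `CCc1ccccc1-n1nncc1CN1C(=O)C2(C(C#N)=C(N)Oc3c(N)cc4nc5ccccc5nc4c32)c2ccccc21` gives 24600 nM in this assay; its number and that of compound 1 sit within the scatter of each other, so no order between them is claimed.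

Compound 4 `CCc1cccc(C)c1-n1nncc1CN1C(=O)C2(C(C#N)=C(N)Oc3c(N)cc4nc5ccccc5nc4c32)c2ccccc21` differs from compound 3 by methyl in place of hydrogen on an aromatic carbon. For the measured compounds named here, the only measured step, from compound 1 to compound 2, also changes the aryl ring on the aromatic nitrogen and is at most a small move, so a small change at most is expected here too, with no direction beyond the scatter. Compound 4 is expected to give about 25000 nM in this assay, between 10000 nM and 60000 nM. The step of a 1.0-fold higher number from compound 3 to compound 4 (0.01 log units; within the scatter) is the estimated result.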

Compound 4, half-maximal inhibitory concentration: > 50000 nM
Compound 4: only a limit was reported; the forecaster's own chance of this, stated with the estimate: 20%; middle value at least 2.0-fold (0.30 log units) away from the limit.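

In this assay compound 4, with 2-ethyl-6-methylphenyl in place of 2-ethylphenyl, gives only a limit, > 50000 nM, and not a number. The step reads an at least 2.0-fold higher number from compound 3 to compound 4 (0.30 log units; that floor lies within the scatter): a single methyl, ortho to a large group and meta to an ethyl group, is enough to lose the measured number of compound 3, but the true size of the change cannot be given and its floor does not establish a direction. Compound 4 and compound 2 now stand at the same limit: the limit of > 50000 nM in this assay, at which 2 of the 4 values shown sit.

The compounds shown leave open what another group on this same aromatic carbon, such as an amine or a fluorine atom, would give. Also open, from the compounds shown here alone, is whether any replacement for this methyl keeps a measured number in this assay.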